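The compounds below may be only part of what the source reports. "The series", "measured", "known", "first", "only" and "open" are said of these compounds alone.

Compound 1, `CNc1nc(Nc2cnn(CCCCCCC(=O)NO)c2)ncc1Cl`: 590 nM
Compound 2, `O=C(CCCCCn1cc(Nc2ncc(Cl)c(Nc3ccccc3Cl)n2)cn1)NO`: 1810 nM
Compound 3, `O=C(/C=C/c1ccc(Cn2cc(Nc3ncc(Cl)c(Nc4ccc(F)cc4)n3)cn2)cc1)NO`: 1030 nM

All three were tested in a functional assay on K562 cells (Homo sapiens) for antiproliferative activity, read by MTT assay, with a stated time of 48 h; a lower number here means a stronger inhibitor, a higher number a weaker inhibitor. Of the three numbers, compound 1 has the lowest. Compound 3 stands within the usual scatter of compound 1, so no order between these two can be read from the numbers. Compound 2 gives a higher number than compound 1, and that gap lies beyond the scatter.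

Compound 4, `O=C(CCCCCCn1cc(Nc2ncc(Cl)c(NC3CC3)n2)cn1)NO`, has not yet been measured. It differs from compound 1 in a single place: cyclopropyl in place of methyl on a nitrogen on an aromatic ring. Within the data shown here, no pair of measured compounds differs by a change of this kind, so there is no measured step of the same type to lean on. Compound 2 and compound 3 each differ from compound 1 in more than one place, so their numbers cannot be resolved into what this one change alone would do. The change is a small one in what is counted, and nothing in the measured set points to a direction. The step of a 1.0-fold higher number from compound 1 to compound 4 (0.01 log units; within the scatter) is therefore expected to stay within the usual scatter. Compound 4 is expected to give about 600 nM in this assay, with a range from 250 nM to 1500 nM.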

Compound 4, half-maximal inhibitory concentration: 380 nM
Compound 4: the middle estimate sits 1.6-fold (0.20 log units) above what was measured; low and high end bracket the measured number.
By their numbers in this assay, from the lowest: compounds 4, 1, 3 and 2 (each within the scatter of the next, the first and the last beyond it).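

Among these compounds, the pair of compound 1 and compound 4 gives the first step in this set that differs in one place only: in this assay the exchange of methylamino for cyclopropylamino gives a 1.6-fold lower number from compound 1 to compound 4 (0.19 log units; within the scatter) and this lies within the usual scatter, so the numbers set no order between the two compounds. At this nitrogen, then, cyclopropyl with its three carbons and its three-membered ring is accepted in place of the single carbon of methyl, with no change that this read-out can resolve. Nothing measured here explains this outcome, and no cause can be assigned to it.

On these data alone, what a free amine, a cyclobutyl group, a tert-butyl group or a hydroxyethyl group would give on the same nitrogen stays open, so the limit of what this position accepts is not yet visible. Compound 2 and compound 3 differ from compound 1 in more than one place, so they cannot show how a larger ring on this nitrogen would act by itself.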